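Glucose analogues as weak glycogen phosphorylase inhibitors

This account rests on a few compounds, and the source may have more. Where it says the series, first, only, none or still open, it means among the compounds named here.

Three glucose-derived compounds have been measured in an assay on isolated protein (Sus scrofa) for inhibition of glycogen phosphorylase, brain form (Homo sapiens); a lower number here means a stronger inhibitor, a higher number a weaker inhibitor. Compound 1 `OC[C@H]1O[C@@](O)(CO)[C@H](O)[C@@H](O)[C@@H]1O` gives 15800000 nM in this assay. Compound 2 `NC[C@H]1O[C@H](CO)[C@@H](O)[C@H](O)[C@H]1O` gives 31600000 nM, and compound 3 `NC(=O)CS[C@H]1O[C@H](CO)[C@@H](O)[C@H](O)[C@H]1O` gives 20000000 nM. Compound 3 therefore holds the second highest of the three numbers; its value and that of compound 1 lie within the scatter of each other, as do its value and that of compound 2, so no order among the three can be read from these numbers. For the measured compounds named here, the only single-point change measured so far is a 1.6-fold lower number from compound 2 to compound 3 (0.20 log units; within the scatter), which did not move the number beyond the scatter.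

Compound 4 `CNNC(=O)[C@H]1O[C@H](CO)[C@@H](O)[C@H](O)[C@H]1O` arises from compound 3 by the change ((methylamino)carbamoyl in place of (carbamoylmethyl)sulfanyl on a saturated ring carbon). Going by the values given here, no measured step covers this particular exchange; the one step that is known, from compound 2 to compound 3, was within the scatter, and all three measured values sit close together. On that basis the step from compound 3 to compound 4 in this assay is expected to be small, with no direction beyond the scatter, as a 1.3-fold lower number from compound 3 to compound 4 (0.12 log units; within the scatter) expresses. Compound 4 is accordingly estimated at 15000000 nM, within a range from 3000000 nM to 60000000 nM.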

Compound 4, inhibition constant: 2000000 nM
Compound 4: the middle estimate sits 7.5-fold (0.88 log units) above what was measured, and the stated range ends above it.
By their numbers in this assay, from the lowest: compound 4; then compounds 1, 3 and 2 (each within the scatter of the next).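

For the compounds shown here, at this position, on a saturated ring carbon next to the ring oxygen, this assay shows a 10-fold lower number from compound 3 to compound 4 (1.00 log units; beyond the scatter) when (methylamino)carbamoyl takes the place of (carbamoylmethyl)sulfanyl, the first exchange here to move the number beyond the scatter, whereas a 1.6-fold lower number from compound 2 to compound 3 (0.20 log units; within the scatter) did not. The same group in place of aminomethyl gives a 16-fold lower number from compound 2 to compound 4 (1.20 log units; beyond the scatter), so the position responds clearly to what it carries, and both routes to compound 4 agree on this even though the two groups it replaces could not be told apart. The entering and leaving groups each count 5 heavy atoms, and nothing available ties the step to any feature of the entering group.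

The compounds shown leave open which part of (methylamino)carbamoyl carries the step, a question that a plain carboxamide, a carboxylic acid or an ethyl group in place of the methyl could begin to separate. They also leave open whether the step would hold with a longer chain on the terminal nitrogen, or whether compound 4 marks the limit of this series.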